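This account rests on a few compounds, and the source may have more. Where it says the series, first, only, none or still open, it means among the compounds named here.

Measured compounds:
- compound 1, `CN(CC(N)=O)C[C@@H]1CCCc2cc(S(=O)(=O)c3cccc(F)c3)ccc21`: 1.26 nM
- compound 2, `COCCNC[C@@H]1CCCc2cc(S(=O)(=O)c3cccc(F)c3)ccc21`: 0.251 nM
- compound 3, `CNCC(=O)NC[C@@H]1CCCc2cc(S(=O)(=O)c3cccc(F)c3)ccc21`: 0.159 nM

All three share one core and differ only in the chain attached to it. In an assay on isolated protein for displacement of a labelled ligand from 5-hydroxytryptamine receptor 6 (Homo sapiens) (on this read-out lower numbers stand for stronger inhibition and higher numbers for weaker inhibition), compound 3 gives the lowest of the three numbers; one step toward it is a 1.6-fold lower number from compound 2 to compound 3 (0.20 log units; within the scatter), the other is a 7.9-fold lower number from compound 1 to compound 3 (0.90 log units; beyond the scatter). The step of a 5.0-fold lower number from compound 1 to compound 2 (0.70 log units; beyond the scatter) shows the same direction.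

Compound 4, `CN(C[C@@H]1CCCc2cc(S(=O)(=O)c3cccc(F)c3)ccc21)C(N)=O`, has not been measured. Its difference from compound 3 is carbamoyl(methyl)amino in place of (((methylamino)methyl)carbonyl)amino on a saturated chain carbon bound to a saturated ring carbon. The measured steps all move among chains that keep a ring-free chain with a nitrogen carrying a hydrogen, and the largest of them was modest; none swaps in a chain of the kind that enters here, with one donor and one acceptor fewer. The expectation is therefore uncertain, leaning toward a higher number: a step of a 31-fold higher number from compound 3 to compound 4 (1.50 log units; beyond the scatter) is estimated. For compound 4 the value in this assay is expected to be about 5 nM, within 0.8 nM to 30 nM.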

Compound 4, inhibition constant: 39.8 nM
Compound 4: the middle estimate sits 8.0-fold (0.90 log units) below what was measured, outside the stated range (above it).
By their numbers in this assay, from the lowest: compounds 3 and 2 (each within the scatter of the next); then compound 1; then compound 4.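

In this assay the position on a saturated chain carbon bound to a saturated ring carbon proves far less tolerant than the earlier, modest steps suggested. Carbamoyl(methyl)amino brings large losses, with a 250-fold higher number from compound 3 to compound 4 (2.40 log units; beyond the scatter) and a 160-fold higher number from compound 2 to compound 4 (2.20 log units; beyond the scatter) on replacing the two chains that gave the lowest numbers. The most telling comparison is a 32-fold higher number from compound 1 to compound 4 (1.50 log units; beyond the scatter) for a single change on the amine nitrogen, where carbamoyl takes the place of carbamoylmethyl, so the length of this group matters greatly and compound 4 is the weakest of the four.

As far as these compounds go, it remains open whether a longer group on that nitrogen, such as carbamoylethyl, or a carboxylic acid in place of the carbamoyl would keep the low numbers. Nothing available here explains the size of these steps.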